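Series notes: isopropyl to cyclohexyl on the chain

The source may report more compounds than this note shows. Statements on the series, on what has been measured and on what is new or still open speak of the compounds shown alone.

Measured compounds:
compound 1 `COc1ccc(C(=O)/C(=C/c2ccc(Cl)cc2Cl)CC(C)OC(C)=O)cc1`, in a functional assay on MCF7 cells (Homo sapiens) for inhibition, read by XTT assay, with a stated time of 48 h (a higher number here means a weaker inhibitor, a lower number a stronger inhibitor), compound 1 gives > 100000 nM, a limit of the assay.
compound 2 `COc1ccc(C(=O)/C(=C/c2ccc(Cl)cc2Cl)CC(C)C)cc1`, in this assay compound 2 gives > 100000 nM, again a limit of the assay.

Within the data shown here, compound 2 stands on no number at all in this assay, only on a limit, and the one further value shown, that of compound 1, is a limit as well. Among the measured compounds shown here, the single measured step, a step that the two limits leave unreadable from compound 1 to compound 2, is left unreadable by the two limits, both of which sit at the limit of > 100000 nM in this assay, at which 2 of the 2 values shown sit.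

Compound 3 `COc1ccc(C(=O)/C(=C/c2ccc(Cl)cc2Cl)CC2CCCCC2)cc1` differs from compound 2 by cyclohexyl in place of isopropyl on a saturated chain carbon bound to a double-bonded chain carbon. For the measured compounds named here, the only step that bears on this change is the unreadable one from the acetoxy to the methyl, so the measured data give no direction and no size for the move to compound 3. With both neighbours at the limit, compound 3 is expected to remain there as well, with the step of a number no higher from compound 2 to compound 3 (the limit leaves the size open) expected to be nothing beyond the scatter. The estimate for compound 3 in this assay is 100000 nM, with a range from 30000 nM to 300000 nM, and most likely only a limit will be reported.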

Compound 3, half-maximal inhibitory concentration: > 100000 nM
Compound 3 was reported as a limit; the forecaster's own chance of this, stated with the estimate: 75%; the middle value sits exactly at the limit.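

No new step can be read among compound 1, compound 2 and compound 3 in this assay, because all three stand on the same limit: the limit of > 100000 nM in this assay, at which 3 of the 3 values shown sit.

The compounds shown leave open whether the isopropyl, cyclohexyl and 1-acetoxyethyl groups differ at all in their effect on inhibition, and where the true value of each compound lies.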